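The source may hold more compounds than are shown below. What is called first, only, known or untested is meant among the compounds shown, and "the series" means these compounds.

In a functional assay on DU-145 cells (Homo sapiens) for inhibition, read by MTT assay, with a stated time of 72 h (a lower number here means a stronger inhibitor, a higher number a weaker inhibitor), three compounds sharing one core and differing in a single group on an aromatic carbon have been measured. Compound 1 `O=C1C=C(N2CCN(c3ccc(Cl)cc3)CC2)C(=O)c2ccccc21` gives 29500 nM, compound 2 `O=C1C=C(N2CCN(c3ccc(F)cc3)CC2)C(=O)c2ccccc21` gives 11700 nM, and compound 3 `Cc1ccc(N2CCN(C3=CC(=O)c4ccccc4C3=O)CC2)cc1` gives 8200 nM. Compound 3 has the lowest number of the three, but its lead is beyond the scatter only against compound 1, as the measured steps show: a 3.6-fold lower number from compound 1 to compound 3 (0.56 log units; beyond the scatter) and a 1.4-fold lower number from compound 2 to compound 3 (0.15 log units; within the scatter).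

Compound 4 `O=C1C=C(N2CCN(c3cccc(Cl)c3)CC2)C(=O)c2ccccc21` has not yet been measured. It carries 3-chlorophenyl in place of 4-methylphenyl on an amine nitrogen in a ring. Among the measured compounds shown here, no measured compound has the 3-chlorophenyl group, so its placement of the chloro is untested. For the measured compounds named here, the nearest guide is compound 1, the only measured compound bearing chloro, and the modest 3.6-fold lower number from compound 1 to compound 3 (0.56 log units; beyond the scatter) suggests that bringing chloro back may raise the number. The step of a 2.5-fold lower number from compound 1 to compound 2 (0.40 log units; beyond the scatter) also leaves compound 1 with the highest value, but that evidence rests on this one chloro compound. A modest move is therefore expected, with the estimate being a 2.2-fold higher number from compound 3 to compound 4 (0.34 log units; beyond the scatter). For compound 4 the estimated value is 18000 nM, with an expected range of 7000 nM to 40000 nM.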

Compound 4, half-maximal inhibitory concentration: 8300 nM
Compound 4: middle estimate off by 2.2-fold (0.34 log units), on the high side; low and high end bracket the measured number.
By their numbers in this assay, from the lowest: compounds 3, 4 and 2 (each within the scatter of the next); then compound 1.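

In this assay, among the compounds shown here, 3-chlorophenyl in place of 4-chlorophenyl on the amine nitrogen in the ring gives the first direct comparison of two chloro placements (a 3.6-fold lower number from compound 1 to compound 4 (0.55 log units; beyond the scatter)), which shows that the high number of compound 1 does not go with chloro as such but with the 4-chlorophenyl group. The 3-chlorophenyl group also sits level with the 4-methylphenyl group (a 1.0-fold higher number from compound 3 to compound 4 (0.01 log units; within the scatter)) and with the 4-fluorophenyl group (a 1.4-fold lower number from compound 2 to compound 4 (0.15 log units; within the scatter)), so among these four compounds only compound 1 stands apart, and compounds 2, 3 and 4 cannot be separated from one another in this assay. Nothing available explains why the placement of chloro matters here.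

Going by these compounds, whether the same change of placement would matter for fluoro or methyl stays open, as does whether the effect seen for chloro would carry over to other cell lines or to a longer or shorter exposure. It is also open how the number would respond to a phenyl ring carrying an amine or a carboxylic acid at this position, since every group shown here keeps a single small substituent on that ring.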